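This account rests on a few compounds, and the source may have more. Where it says the series, first, only, none or still open, it means among the compounds named here.

Measured compounds and values:
compound 1, `CC(C)[C@@H](N)C(=O)NCc1ccc(F)cc1`: in a functional assay on the whole organism (strain albino Sprague-Dawley) with Rattus norvegicus as the target, in the maximal electroshock model (on this read-out higher numbers stand for an effect only at larger amounts of compound and lower numbers for an effect already at smaller amounts), compound 1 gives 21 mg/kg
compound 2, `CC(C)[C@@H](N)C(=O)NCc1ccc(C(F)(F)F)cc1`: in this assay compound 2 gives 13 mg/kg
compound 3, `CC(C)[C@@H](N)C(=O)NCc1ccc(Cl)cc1`: in this assay compound 3 gives "not determined" (no result reported)

All three share one core and differ only in the group carried on the aromatic ring. For compound 3 no number is available in this assay, so it cannot be placed relative to compound 1 or compound 2. The step to compound 4, `CC(C)[C@@H](N)C(=O)NCc1ccc(-c2ccccc2)cc1`, is phenyl in place of chloro on an aromatic carbon. Within the data shown here, the only measured step, a 1.6-fold lower number from compound 1 to compound 2 (0.21 log units; within the scatter), exchanged one small group for another and stayed within the scatter; it does not involve chloro or phenyl, so it gives no direct guidance on how a much larger group at this position behaves in this assay. Among the measured compounds shown here, with compound 3 unmeasured and no comparable step available, the expectation for compound 4 rests on the values of compound 1 and compound 2 alone, and is accordingly wide. Compound 4 is estimated to give 25 mg/kg, with a range from 8 mg/kg to 90 mg/kg.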

Compound 4, dose for half-maximal effect: 30 mg/kg
Beside the measured number, compound 4's estimate is 1.2-fold (0.08 log units) below it, and the stated range covers the measured number.
By their numbers in this assay, from the lowest: compounds 2, 1 and 4 (each within the scatter of the next, the first and the last beyond it).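

In this assay, the position on the aromatic ring accepts a whole phenyl ring and the compound stays active: phenyl in place of fluoro gives a 1.4-fold higher number from compound 1 to compound 4 (0.15 log units; within the scatter), so the two cannot be told apart. Phenyl in place of trifluoromethyl gives a 2.3-fold higher number from compound 2 to compound 4 (0.36 log units; beyond the scatter), the first step in this small set that lies beyond the scatter, though only modestly, and it shows that the group at this position can make a measurable difference. No supporting data are available to explain either step.

The step from chloro to phenyl cannot be read, since compound 3 has no number. Going by these compounds, it also remains open how this position would respond to an amine, a carboxylic acid or a longer alkyl chain, or to a group placed elsewhere on the ring.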